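The source may hold more compounds than are shown below. What is called first, only, known or untested is meant among the compounds shown, and "the series" means these compounds.

In a functional assay on MDCK cells (Canis lupus familiaris) for inhibition (on this read-out lower numbers stand for higher toxicity in this test and higher numbers for lower toxicity in this test), compound 1 `Cn1c(CC2(C)CO2)cc(=O)n(C)c1=O` gives 4000 nM, compound 2 `COc1nc(CC2(c3ccccc3)CCCO2)cc(=O)n1C` gives 130000 nM, and compound 3 `COc1nc(CC2(C)CCCO2)cc(=O)n1C` gives 1620000 nM, the highest number of the three. Compound 4 `CCCCOc1nc(CC2(C)CCCO2)cc(=O)n1C` carries propyl in place of hydrogen on a saturated chain carbon bound to an oxygen on an aromatic ring, which reads as methoxy to butoxy. Going by the values given here, no measured step covers this place. The nearest evidence is a 12-fold higher number from compound 2 to compound 3 (1.10 log units; beyond the scatter), a large step for methyl in place of phenyl on a saturated ring carbon, which leaves the phenyl compound 2 with the lower number. By loose analogy only, a moderate move towards a lower number is expected in this assay, with wide uncertainty. The expected change is a 4.6-fold lower number from compound 3 to compound 4 (0.67 log units; beyond the scatter). Compound 4 is estimated at 350000 nM, with an expected range of 70000 nM to 1500000 nM.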

Compound 4, half-maximal cytotoxic concentration: 1080000 nM
Compound 4: the middle estimate sits 3.1-fold (0.49 log units) below what was measured, within the range that was stated.
By their numbers in this assay, from the lowest: compound 1; then compound 2; then compounds 4 and 3 (each within the scatter of the next).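

In this assay the change from methoxy to butoxy gives a 1.5-fold lower number from compound 3 to compound 4 (0.18 log units; within the scatter), so propyl in place of hydrogen on a saturated chain carbon bound to an oxygen on an aromatic ring leaves the read-out within the scatter. Going by these compounds alone, this is the first reading at this place, and it shows that the series tolerates butoxy here without a measurable shift in this test. No supporting measurement explains this result. As far as these compounds go, whether a longer chain or an amine in place of butoxy would also leave the number unchanged remains open. Also open, from the compounds shown here alone, is whether butoxy would behave the same alongside the phenyl of compound 2.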